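The source may report more compounds than this note shows. Statements on the series, on what has been measured and on what is new or still open speak of the compounds shown alone.

Measured in a functional assay on DU-145 cells (Homo sapiens) for inhibition, read by WST assay, with a stated time of 3 days; a higher number here means a weaker inhibitor, a lower number a stronger inhibitor:
- compound 1 `CCCCn1ccnc1/C=C/C(=O)/C=C/c1coc2ccccc2c1=O`: 4300 nM
- compound 2 `CC(C)CCn1ccnc1/C=C/C(=O)/C=C/c1coc2ccccc2c1=O`: 5800 nM

Compound 2, at 5800 nM, lies within the scatter of compound 1. Compound 3 `CCC(CC)n1ccnc1/C=C/C(=O)/C=C/c1coc2ccccc2c1=O` has pentan-3-yl in place of isopentyl on an aromatic nitrogen. Among the measured compounds shown here, only one measured step bears on this change, a 1.3-fold higher number from compound 1 to compound 2 (0.13 log units; within the scatter), and it also alters the chain on that nitrogen. For the measured compounds named here, no measured compound carries pentan-3-yl, so this evidence is thin. In this assay, no change beyond the scatter is expected, and the expected step is a 1.0-fold higher number from compound 2 to compound 3 (0.01 log units; within the scatter). The estimate for compound 3 is 6000 nM, with an expected range of 2800 nM to 13000 nM.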

Compound 3, half-maximal inhibitory concentration: 5200 nM
Compound 3: the middle estimate sits 1.2-fold (0.06 log units) above what was measured, and the stated range covers the measured number.
By their numbers in this assay, from the lowest: compounds 1, 3 and 2 (each within the scatter of the next).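

In this assay, pentan-3-yl on an aromatic nitrogen gives a 1.1-fold lower number from compound 2 to compound 3 (0.05 log units; within the scatter) and a 1.2-fold higher number from compound 1 to compound 3 (0.08 log units; within the scatter). Butyl, isopentyl and pentan-3-yl therefore cannot be told apart at this position, so the tolerance seen with the earlier pair now extends to a third five-or-fewer-carbon chain shape. No evidence at hand accounts for this flat result.

Going by these compounds, whether an amine or a carboxylic acid on this nitrogen would give a step beyond the scatter remains open. The same holds for a phenyl ring or a much longer chain such as decyl.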